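Propargylsulfanyl to benzylsulfanyl: working notes on compound 4

The source may hold more compounds than are shown below. What is called first, only, known or untested is meant among the compounds shown, and "the series" means these compounds.

Measured so far in a functional assay on MCF7 cells (Homo sapiens) for antiproliferative activity, read by MTT assay, with a stated time of 72 h; on this read-out lower numbers stand for stronger inhibition and higher numbers for weaker inhibition:
- compound 1, `CCCSc1nc(N/N=C/c2ccc(Cl)cc2)c2nnn(Cc3ccccc3)c2n1`, gives > 64000 nM, which is a limit of the assay and not a number.
- compound 2, `C#CCSc1nc(N/N=C(\C)c2ccccc2O)c2nnn(Cc3ccccc3)c2n1`, gives 11300 nM.
- compound 3, `C#CCSc1nc(N/N=C/c2cc(OC)c(OC)c(OC)c2)c2nnn(Cc3ccccc3)c2n1`, gives 17000 nM.

Of the two numbers in hand, compound 2 carries the lower one, but compound 3 sits within the usual scatter of it, so no order between compound 2 and compound 3 can be read from this assay. Compound 1 stands apart only as a limit; see (the limit of > 64000 nM in this assay, at which 1 of the 3 values shown sits).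

Compound 4, `C/C(=N\Nc1nc(SCc2ccccc2)nc2c1nnn2Cc1ccccc1)c1ccccc1O`, is not yet measured. It differs from compound 2 in one place: phenyl in place of ethynyl on a saturated chain carbon bound to a sulfur. Within the data shown here, no pair of measured compounds differs by this change alone, so the size of the step has no direct precedent here; compound 1 carries a different sulfur substituent but also a different hydrazone partner and gives only a limit.

The step from compound 2 to compound 4 is expected to be small, a 1.2-fold higher number from compound 2 to compound 4 (0.06 log units; within the scatter), not beyond the scatter in either direction. Compound 4 is therefore estimated at 13000 nM in this assay, within a range of 4000 nM to 45000 nM.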

Compound 4, half-maximal inhibitory concentration: 950 nM
Compound 4: the middle estimate sits 14-fold (1.14 log units) above what was measured; measured number outside the range, below it.
By their numbers in this assay, from the lowest: compound 4; then compounds 2 and 3 (each within the scatter of the next). At a limit, above all of these: compound 1.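

In this assay, the place on a saturated chain carbon bound to a sulfur turns out to matter: phenyl in place of ethynyl gives a 12-fold lower number from compound 2 to compound 4 (1.08 log units; beyond the scatter), while the hydrazone partner and the rest of the core stay the same. Among these compounds, until compound 4, no two compounds differed in one place, so this is the first change whose size can be read directly, and it rests on this single pair, in one assay and with one hydrazone partner. The values in hand show the size of the step but offer nothing that accounts for it.

From the compounds shown here alone, it remains open whether the step belongs to the aromatic ring itself or simply to a larger group, which a cyclohexylmethyl group or a longer chain such as phenethyl in the same place would help to separate, and whether an amine or a carboxylic acid on the phenyl ring would keep the lower number. Going by these compounds, it is also open whether propargylsulfanyl to benzylsulfanyl gives a step of similar size with the hydrazone partner of compound 3, since this pair shows it with the partner of compound 2 only.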